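This account rests on a few compounds, and the source may have more. Where it says the series, first, only, none or still open, it means among the compounds named here.

The study brings together four compounds built on one shared core. Compound 1 `COc1cccc(N2C(=O)COc3ccc(-c4cnc(Cl)c(NS(=O)(=O)c5ccc(F)cc5)c4)cc32)c1` and compound 3 `COc1ccc(N2C(=O)COc3ccc(-c4cnc(OC)c(NS(=O)(=O)c5ccc(F)cc5)c4)cc32)cc1` carry a sulfonamide-bearing aromatic group at one end of the core, while compound 2 `Cc1ccc(N2C(=O)COc3ccc(-c4cnc5ccccc5c4)cc32)cc1` and compound 4 `O=C1COc2ccc(-c3cnc4ccccc4c3)cc2N1c1ccc(Cl)cc1` carry a simpler aromatic group in that position and differ from each other only in the group on the other end.

In a functional assay on HepG2 cells (Homo sapiens) for antiproliferative activity, read by MTT assay, with a stated time of 72 h (a lower number here means a stronger inhibitor, a higher number a weaker inhibitor), compound 1 gives no number, only a limit of the assay, > 40000 nM. Compound 2 likewise reaches only the limit in this assay, > 40000 nM. Among the measured compounds shown here, compound 3 is the single compound of the three that returns a number in this assay, 13100 nM. Compound 2 therefore stands at the weak edge of what was measured, sharing (the limit of > 40000 nM in this assay, at which 2 of the 3 values shown sit).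

The step from compound 2 to compound 4 is a small one: chloro in place of methyl on an aromatic carbon. For the measured compounds named here, no measured pair in the set shows what this change does, so nothing supports a move of any size. The expected step from compound 2 to compound 4 is a step that the limit leaves unreadable from compound 2 to compound 4, that is, none beyond the scatter. Compound 4 is expected in this assay to give about 45000 nM, somewhere between 15000 nM and 120000 nM, and most likely the assay will again report only a limit for compound 4.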

Compound 4, half-maximal inhibitory concentration: 32700 nM
For compound 4 the middle estimate is 1.4-fold (0.14 log units) above the measured one, within the range that was stated.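

With 4-chlorophenyl in place of 4-methylphenyl, compound 4 gives an actual number in this assay, 32700 nM, so this position now has a readable value among the compounds with the simpler aromatic group. Compound 2 offered only a limit. The change amounts to an at least 1.2-fold lower number from compound 2 to compound 4 (0.08 log units; that floor lies within the scatter), so a real difference between chloro and methyl at this place is not shown, though a larger one is not ruled out. The true size of the step stays unknown because compound 2 has no number of its own: the limit of > 40000 nM in this assay, at which 2 of the 4 values shown sit.

The compounds shown leave open how a quite different group at this place on the ring, such as a carboxylic acid or a dimethylamino group, would read in this assay. Also open, from the compounds shown here alone, is whether chloro in place of methyl would give a similar step in compounds with the sulfonamide-bearing aromatic group of compound 1 and compound 3, as neither of these carries chloro or methyl at this place.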